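The compounds below may be only part of what the source reports. "The series", "measured", "known", "first", "only" and "open" are said of these compounds alone.

Compound 3 `CN(C)C(=O)c1cc2cnc(Nc3ccc(NC(=O)C4(C(=O)Nc5cccc(F)c5)CC4)cc3)nc2n1C1CCCC1` was tested in a functional assay on NCI-H1299 cells (Homo sapiens) for inhibition, read by CCK-8 assay, with a stated time of 72 h, tested at 1 uM (on this read-out lower numbers stand for less inhibition of growth and higher numbers for more inhibition of growth at the one concentration tested), where compound 3 gives 64.2%. Among the three measured compounds it stands second highest: compound 2 `CN(C)C(=O)c1cc2cnc(Nc3ccc(NC(=O)C4(C(=O)Nc5ccc(O)cc5)CC4)cc3)nc2n1C1CCCC1` gives 87.4%, and compound 1 `CN(C)C(=O)c1cc2cnc(Nc3ccc(NC(=O)C4(C(=O)Nc5ccc(Cl)c(C(F)(F)F)c5)CC4)cc3)nc2n1C1CCCC1` gives 39.5%. Compound 4 `CN(C)C(=O)c1cc2cnc(Nc3ccc(NC(=O)C4(C(=O)Nc5ccc(Cl)cc5)CC4)cc3)nc2n1C1CCCC1` has not yet been measured; it differs from compound 3 by 4-chlorophenyl in place of 3-fluorophenyl on an amide-type nitrogen. Among the measured compounds shown here, one measured step bears on this change: a number 24.7 percentage points higher from compound 1 to compound 3 (beyond the scatter). The group that left in that step, 4-chloro-3-(trifluoromethyl)phenyl, itself contains chlorine, while compound 4 carries chlorine without trifluoromethyl, so its number is expected to fall between those two, a modest drop being estimated: a number 9.2 percentage points lower from compound 3 to compound 4 (within the scatter). Compound 4 is therefore expected to give about 55%, within a range from 35% to 75%.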

Compound 4, percent growth inhibition at one concentration: 52.2%
The estimate for compound 4 lay 2.8 percentage points above the measured number; the measured number falls inside the stated range.
By their numbers in this assay, from the lowest: compound 1; then compound 4; then compound 3; then compound 2.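

In this assay, hydrogen in place of trifluoromethyl on the chlorinated ring gives a clear gain (a number 12.7 percentage points higher from compound 1 to compound 4 (beyond the scatter)), so the effect of trifluoromethyl can now be read apart from that of chlorine. Chlorine still falls short of hydroxy (a number 35.2 percentage points lower from compound 2 to compound 4 (beyond the scatter)), and 4-chlorophenyl falls short of 3-fluorophenyl (a number 12 percentage points lower from compound 3 to compound 4 (beyond the scatter)), although that step changes both the halogen and its place on the ring. Nothing available here explains these differences. A 4-fluorophenyl group would separate the halogen from its place. Going by these compounds, whether 4-aminophenyl or 4-methoxyphenyl could match the 4-hydroxyphenyl of compound 2 stays open.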